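Carbamate ester variation on the pyrrolidine carbamate

The compounds below may be only part of what the source reports. "The series", "measured", "known", "first", "only" and "open" are said of these compounds alone.

Two members of the series have numbers in an assay on HEK293 cells for displacement of a labelled ligand from Melanocortin receptor 4 (Homo sapiens); on this read-out lower numbers stand for stronger inhibition and higher numbers for weaker inhibition. Compound 1 `CC(=O)N1CC[C@H](c2ccc(F)cc2)[C@@H]1C(=O)N1CCN(c2ccc(C)cc2[C@@H](N)C(C)C)CC1` gives 330 nM in this assay. Compound 2 `CCOC(=O)N1CC[C@H](c2ccc(Cl)cc2)[C@H]1C(=O)N1CCN(c2ccc(C)cc2[C@@H](N)C(C)C)CC1` gives 42 nM in this assay, the lowest of the two numbers; compound 1 sits at the higher number, and the gap between the two lies beyond the usual scatter. The two compounds differ in more than one place, so no single step can be read from them.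

Compound 3 `Cc1ccc(N2CCN(C(=O)[C@@H]3[C@@H](c4ccc(Cl)cc4)CCN3C(=O)OC(C)C)CC2)c([C@@H](N)C(C)C)c1` is the next compound to be measured in this assay. Compared with compound 2, the change is methyl in place of hydrogen on a saturated chain carbon bound to an oxygen next to a carbonyl group and a saturated chain carbon, so the ethoxycarbonyl group becomes an isopropoxycarbonyl group. Nothing measured in the series bears on this change. The expected step, a 1.2-fold lower number from compound 2 to compound 3 (0.08 log units; within the scatter), is small, in no direction beyond the scatter. For compound 3 the estimate in this assay is 35 nM, with a range from 14 nM to 90 nM.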

Compound 3, inhibition constant: 68 nM
Compound 3: the middle estimate sits 1.9-fold (0.29 log units) below what was measured; the range from low to high includes it.
By their numbers in this assay, from the lowest: compounds 2 and 3 (each within the scatter of the next); then compound 1.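

In this assay, the change from ethoxycarbonyl to isopropoxycarbonyl gives a 1.6-fold higher number from compound 2 to compound 3 (0.21 log units; within the scatter). Among the compounds shown here, this is the only single-place step so far, and it places compound 2 and compound 3 within the scatter of each other. In this one pair, methyl in place of hydrogen on a saturated chain carbon bound to an oxygen next to a carbonyl group and a saturated chain carbon leaves the binding read-out unresolved from that of the ethoxycarbonyl parent.

The compounds shown leave open whether a longer chain, such as an n-butyl ester, or a benzyl ester at this place would keep the number in this range, and the steps from compound 1 to the other two cannot be read. No independent evidence bears on this step.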